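Swapping Trifluoromethyl for Chloro on Two Different Cores

The source may report more compounds than this note shows. Statements on the series, on what has been measured and on what is new or still open speak of the compounds shown alone.

Of the compounds shown here, three have been measured in a physicochemical assay for lipophilicity, at pH 7.4; on this read-out lower numbers stand for lower lipophilicity and higher numbers for higher lipophilicity. Compound 1 `CC(C(=O)O)c1nn(Cc2cn3cc(OCC4CC4)c(Cl)cc3n2)c2ccccc2c1=O` and compound 2 `CC(C(=O)O)c1nn(Cc2cn3cc(OCC4CC4)c(C(F)(F)F)cc3n2)c2ccccc2c1=O` share one core; compound 3 `O=C(O)Cn1nc(Cc2nc3cc(C(F)(F)F)c(OCC4CC4)cc3[nH]2)c2ccccc2c1=O` is built on a second core, and the difference between the two cores is not broken down here. In this assay compound 1 gives 2.44. In this assay compound 2 gives 2.99. In this assay compound 3 gives 2.79, which places it second highest of the three, close to compound 2 and further from compound 1.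

For the measured compounds named here, the one measured step within a shared core is chloro in place of trifluoromethyl on an aromatic carbon. On this read-out it made a number 0.55 log units lower from compound 2 to compound 1 (beyond the scatter).

Compound 4 `O=C(O)Cn1nc(Cc2nc3cc(Cl)c(OCC4CC4)cc3[nH]2)c2ccccc2c1=O` is not yet measured. Its relation to compound 3 is chloro in place of trifluoromethyl on an aromatic carbon. The leaving and entering groups are the same as before, but the surroundings are not identical: in compound 2 the six-membered aromatic ring carrying the group holds one nitrogen and the group sits opposite the ring nitrogen, while in compound 3 that ring is of carbon only. Going by the values given here, the change from compound 3 to compound 4 is therefore the same kind of change as the one from compound 2 to compound 1, not the same change.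

The step is expected to be a number 0.49 log units lower from compound 3 to compound 4 (beyond the scatter), because the measured counterpart was a number 0.55 log units lower from compound 2 to compound 1 (beyond the scatter). Compound 4 is thus estimated at 2.3, most likely from 1.95 to 2.65.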

Compound 4, distribution coefficient: 2.21
Beside the measured number, compound 4's estimate is 0.09 log units above it; low and high end bracket the measured number.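

In this assay, chloro in place of trifluoromethyl on an aromatic carbon gave a number 0.58 log units lower from compound 3 to compound 4 (beyond the scatter) on one core and a number 0.55 log units lower from compound 2 to compound 1 (beyond the scatter) on the other, so the change went in the same direction on both cores and lay beyond the usual scatter each time. For the compounds shown here, this shows that, for these two pairs, a step measured on one core was a fair guide to the same kind of change on the other, even though the ring carrying the group differs; with only two pairs, it does not establish a rule for other cores or other changes. Nothing measured here explains why the two steps agree, and no information on the cause is available.

The compounds shown leave open how a nitrile or a methyl group on that same aromatic carbon would read in this assay on either core. On these data alone, all four compounds also carry cyclopropylmethoxy, so it remains open whether the exchange of trifluoromethyl for chloro would give a similar step with an amine or a longer chain in its place.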